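A few compounds are considered here, and "the series" means these few. Any claim that something is new, unique, unknown or untested is made for them only; others in the source may bear on it.

Measured so far:
- Compound 1 `CCCCOC(=O)C(=O)C(CC)NC(=O)C(CC(C)C)NC(=O)OCc1ccccc1`: 28000 nM
- Compound 2 `CCOC(=O)C(=O)C(CC)NC(=O)C(CC(C)C)NC(=O)C(CC)Oc1ccccc1`: 22000 nM
- Compound 3 `CCCC(NC(=O)C(CC(C)C)NC(=O)OCc1ccccc1)C(=O)C(=O)NCC`: 40000 nM

All three compounds were tested in a functional assay for inhibition, with Rattus norvegicus as the target, at pH 7.35; a higher number here means a weaker inhibitor, a lower number a stronger inhibitor. Compound 1 gives 28000 nM, which lies within the usual scatter of the values of both other compounds. On these numbers, the three cannot be ranked against one another.

The next compound to be tested is compound 4 `CCC(NC(=O)C(CC(C)C)NC(=O)OCc1ccccc1)C(=O)C(=O)O`. It comes from compound 1 by placing hydrogen in place of butyl on an oxygen next to a carbonyl group, which turns butoxycarbonyl into carboxy: hydrogen in place of butyl on an oxygen next to a carbonyl group.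

Among the compounds with values here, no two measured compounds differ in one place only, and none of them carries the carboxy group, so the data offer no direct measure of this change. They do offer one loose guide. The end of the molecule varies among the three, yet compound 2 at 22000 nM and compound 3 at 40000 nM remain within the scatter of compound 1, so a very large step seems unlikely. Even so, removing the whole butyl is a bigger change than any clean comparison available here can cover, and the uncertainty is wide.

The expected change is a 1.8-fold higher number from compound 1 to compound 4 (0.25 log units; within the scatter), a modest move towards a weaker inhibitor. For compound 4 the estimated value is 50000 nM, with an expected range from 15000 nM to 200000 nM.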

Compound 4, half-maximal inhibitory concentration: 100000 nM
The estimate for compound 4 lay 2.0-fold (0.30 log units) below the measured number; the measured number falls inside the stated range.
By their numbers in this assay, from the lowest: compounds 2, 1 and 3 (each within the scatter of the next); then compound 4.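

In this assay, within the data shown here, hydrogen in place of butyl on an oxygen next to a carbonyl group gives a 3.6-fold higher number from compound 1 to compound 4 (0.55 log units; beyond the scatter) and so turns butoxycarbonyl into carboxy, and this is the first single change that can be read on its own. The earlier numbers all lay within the scatter of compound 1 and gave no hint of how much this end of the molecule matters, whereas compound 4 at 100000 nM stands clearly apart from it, so here losing the butyl costs inhibition by more than the scatter. No measurement shown here accounts for this loss of inhibition.

One step cannot tell whether the butyl chain itself counts, or whether any group in place of the hydrogen of the carboxy would do: a small methyl could bring the number back to that of compound 1 or leave it near that of compound 4, and a longer chain such as hexyl could go either way. From the compounds shown here alone, whether the same change would move the number by a similar amount on a different core also stays open.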